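The compounds below may be only part of what the source reports. "The series", "measured", "known", "first", "only" and "open" are said of these compounds alone.

Going by the values given here, in an ADME assay on THP-1 cells (Homo sapiens) for inhibition, read by MTT assay (on this read-out higher numbers stand for weaker inhibition of growth and lower numbers for stronger inhibition of growth), compound 1 `CCCCCCc1cc2c(=O)n(CCCSc3nc(-c4cc(OC)c(OC)c(OC)c4)c(C#N)c(=O)[nH]3)cnc2s1` gives 54.3 ug/mL, the only plain number among the values shown. Compound 2 `COc1cc(-c2[nH]c(=S)[nH]c(=O)c2C#N)cc(OC)c1OC` gives only a limit of the assay, > 100 ug/mL; its value is the limit of > 100 ug/mL in this assay, at which 1 of the 2 values shown sits. Compound 3 `CCCc1cc2c(=O)n(CCCSc3nc(-c4cc(OC)c(OC)c(OC)c4)c(C#N)c(=O)[nH]3)cnc2s1` differs from compound 1 by hydrogen in place of propyl on a saturated chain carbon, three bonds along the chain from an aromatic carbon. Among the compounds with values here, no measured pair shows what such a shortening does here, and the expected step of a 1.4-fold higher number from compound 1 to compound 3 (0.14 log units; within the scatter) is therefore taken as a small one toward weaker inhibition of growth, roughly at the edge of the usual scatter. On that basis compound 3 is expected to give 75 ug/mL, with a likely range from 30 ug/mL to 150 ug/mL.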

Compound 3, concentration for 50% growth inhibition: > 100 ug/mL
Compound 3 was reported as a limit (the forecaster's own chance of this, stated with the estimate: 25%); middle value at least 1.3-fold (0.12 log units) away from the limit.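

Cutting hexyl to propyl gives the first measured step at this position in this assay: an at least 1.8-fold higher number from compound 1 to compound 3 (0.26 log units; that floor lies within the scatter). From the compounds shown here alone, the value of compound 3 is a limit, so this step is only a floor and its true size stays unknown. Most of the values shown now end at the same point: the limit of > 100 ug/mL in this assay, at which 2 of the 3 values shown sit.

Still open, going by these compounds, is whether a longer chain such as octyl, in place of the hexyl, would give a lower number than compound 1. Also open, on these data alone, is what an amine or a carboxylic acid would do there.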